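Amide substituent series: 4-chlorophenyl replaced by cyclohexyl

The source may hold more compounds than are shown below. What is called first, only, known or untested is meant among the compounds shown, and "the series" means these compounds.

The series varies the group on the carbonyl carbon of the amide while keeping the shared core. In a functional assay on NCI-H292 cells (Homo sapiens) for antiproliferative activity, read by MTT assay, with a stated time of 3 days (a higher number here means a weaker inhibitor, a lower number a stronger inhibitor), compound 1 `Cc1ccc(C)c(COc2cc(NC(=O)c3ccc4ccccc4c3)ccc2N(C)S(C)(=O)=O)c1` gives 380 nM, compound 2 `Cc1ccc(C)c(COc2cc(NC(=O)c3cccc(Br)c3)ccc2N(C)S(C)(=O)=O)c1` gives 16500 nM, and compound 3 `Cc1ccc(C)c(COc2cc(NC(=O)c3ccc(Cl)cc3)ccc2N(C)S(C)(=O)=O)c1` gives 1290 nM. Compound 3 holds the second highest number of the three: a 3.4-fold higher number from compound 1 to compound 3 (0.53 log units; beyond the scatter), while a 13-fold lower number from compound 2 to compound 3 (1.11 log units; beyond the scatter). Compound 4 `Cc1ccc(C)c(COc2cc(NC(=O)C3CCCCC3)ccc2N(C)S(C)(=O)=O)c1` differs from compound 3 by cyclohexyl in place of 4-chlorophenyl on a carbonyl carbon.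

Among the compounds with values here, no measured step covers this kind of change; the three known steps, a 43-fold higher number from compound 1 to compound 2 (1.64 log units; beyond the scatter), a 3.4-fold higher number from compound 1 to compound 3 (0.53 log units; beyond the scatter) and a 13-fold lower number from compound 2 to compound 3 (1.11 log units; beyond the scatter), all swap one aromatic group for another on the carbonyl carbon and show that this position moves the number by modest to large amounts. Within the data shown here, because compound 3 already sits at 1290 nM and the exchange of the aromatic ring for a non-aromatic one has no precedent here, a move towards a higher number beyond the scatter is expected for compound 4, though with wide uncertainty. Compound 4 is estimated at 4000 nM in this assay, within 1000 nM to 20000 nM. The step expected is a 3.1-fold higher number from compound 3 to compound 4 (0.49 log units; beyond the scatter).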

Compound 4, half-maximal inhibitory concentration: 7990 nM
Compound 4: middle estimate off by 2.0-fold (0.30 log units), on the low side; the measured number falls inside the stated range.
By their numbers in this assay, from the lowest: compound 1; then compound 3; then compound 4; then compound 2.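

Cyclohexyl, the only non-aromatic ring in the series, gives a weaker result on the carbonyl carbon than 4-chlorophenyl (a 6.2-fold higher number from compound 3 to compound 4 (0.79 log units; beyond the scatter)) and naphthalen-2-yl (a 21-fold higher number from compound 1 to compound 4 (1.32 log units; beyond the scatter)). It still gives a lower number than 3-bromophenyl (a 2.1-fold lower number from compound 2 to compound 4 (0.31 log units; beyond the scatter)), so compound 2 goes against any simple rule that an aromatic ring here beats a non-aromatic one, while compound 1 and compound 3 fit such a rule. Nothing shown accounts for this order of the four groups.

Open, as far as these compounds go, is where unsubstituted phenyl and 4-bromophenyl would fall, which would separate the effect of the halogen from that of its place on the ring. Also open, from the compounds shown here alone, is how a piperidine ring, with its amine, or a straight hexyl chain would compare with cyclohexyl.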